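A few compounds are considered here, and "the series" means these few. Any claim that something is new, unique, unknown or untested is made for them only; others in the source may bear on it.

Measured compounds:
Compound 1, `FC(F)(F)c1ccc2[nH]c(-c3ccccc3)nc2c1`, gives 1200 nM in a functional assay for antagonist activity at Neuropeptides B/W receptor type 1 (Homo sapiens), read by cAMP accumulation; a lower number here means a stronger inhibitor, a higher number a weaker inhibitor.
Compound 2, `O=[N+]([O-])c1ccc2nc(-c3ccc(Cl)cc3Cl)[nH]c2c1`, gives 2880 nM in this assay.
Compound 3, `CC(C)(C)c1ccc(-c2nc3cc([N+](=O)[O-])ccc3[nH]2)cc1`, gives 3180 nM in this assay.

Among the three measured compounds, compound 1 has the lowest number in this assay. Its gap to compound 2, the nearest of the other two, lies beyond the usual scatter, and its gap to compound 3, the furthest, also lies beyond the scatter, so compound 1 is the strongest inhibitor of this small set.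

The step that follows leads from compound 1 to compound 4, `FC(F)(F)c1ccc2[nH]c(-c3ccc(-c4ccoc4)cc3)nc2c1`, which has not yet been measured in this assay. The two structures differ in one place: furan-3-yl in place of hydrogen on an aromatic carbon

Among the measured compounds shown here, no pair of measured compounds differs in a single place, so there is no measured step to lean on for this change. For the measured compounds named here, the three measured compounds differ from one another in several positions at once, and what they show is only that compound 1 sits at the low end of the range.

Given the absence of any comparable step, compound 4 is expected to stay close to compound 1, with a step of a 1.5-fold lower number from compound 1 to compound 4 (0.18 log units; within the scatter) that is likely within the scatter or, at most, a modest move in either direction. The estimate for compound 4 in this assay is 800 nM, with a range from 200 nM to 4000 nM.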

Compound 4, half-maximal inhibitory concentration: 1190 nM
Estimate against measurement, compound 4: 1.5-fold (0.17 log units) below; the measured number falls inside the stated range.
By their numbers in this assay, from the lowest: compounds 4 and 1 (each within the scatter of the next); then compounds 2 and 3 (each within the scatter of the next).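

In this assay, among the compounds shown here, the change reads as a 1.0-fold lower number from compound 1 to compound 4 (0.00 log units; within the scatter), the first reading in this set of a change made in a single place. The earlier compounds shown here differ from one another in several positions at once, so they could say nothing about this position taken alone. Compound 4 shows that, on the core of compound 1, furan-3-yl can stand on this aromatic carbon, para to a large group, with the number staying within the scatter of the hydrogen compound, although this one step cannot show whether the position is generally tolerant. Nothing among the data offers a measured property or other information that would account for this result.

The compounds shown leave open whether the same position would respond differently to an amine, a carboxylic acid or a longer chain, or to a six-membered aromatic ring in place of the furan-3-yl group. They also leave open whether furan-3-yl would give the same result if the trifluoromethyl group of the core were replaced by a nitro group.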